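This account rests on a few compounds, and the source may have more. Where it says the series, first, only, none or still open, it means among the compounds named here.

Two compounds share a core in which a thiazole-like heterocycle bears a chlorophenyl group and a hydrazone-linked aromatic ring; the first is compound 1 `Clc1ccc(-c2csc(N/N=C/c3ccccc3)n2)cc1` and the second compound 2 `COc1ccc(/C=N/Nc2nc(-c3ccc(Cl)cc3)cs2)cc1OC`. In an in vitro assay on BTI-TN-5B1-4 cells for inhibition of Amine oxidase [flavin-containing] A (Homo sapiens), read by fluorescence, with a stated time of 15 min, tested at 100 uM (a lower number here means less inhibition, a higher number more inhibition at the concentration tested (going by the name of the read-out)), compound 1 gives 40%, and in the same test compound 2 gives 40%. Compound 2 thus stands level with compound 1 at the digits shown, the two values lying within the usual scatter of this measurement.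

Compound 3 `COc1ccc(/C=N/Nc2nc(-c3ccc(Cl)cc3)cs2)cc1` has not yet been measured. Going by the values given here, the single difference from compound 2 is hydrogen in place of methoxy on an aromatic carbon. Since the two measured compounds, which differ by two methoxy groups, give values within the scatter of each other, no step beyond the scatter is expected here either, in either direction. The estimated result for compound 3 in this assay is 40%, spanning 25% to 55%, which would mean a step of no change at the digits printed from compound 2 to compound 3 (within the scatter).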

Compound 3, a percentage reported as inhibition, at one concentration (the size of the read-out at that concentration, not a potency): 40%
For compound 3 middle estimate and measured number coincide at the digits printed, within the range that was stated.
By their numbers in this assay, from the lowest: compounds 1, 2 and 3 (each within the scatter of the next).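

In this assay the methoxy group ortho to a methoxy group and meta to a large group can be swapped for hydrogen with no change at the digits printed from compound 2 to compound 3 (within the scatter) as the outcome, so the read-out does not register this change at this position. Putting methoxy in place of hydrogen on an aromatic carbon of compound 1 gives no change at the digits printed from compound 1 to compound 3 (within the scatter) as the result, which shows the effect of a single methoxy group, whereas the earlier pair differed by two methoxy groups at once. No other data here bear on what lies behind these matching values.

Going by these compounds, the ring carries only hydrogen or methoxy in these compounds, so it remains open whether an amine, a carboxylic acid or a longer chain would move the read-out beyond the scatter. The readings also come from a single concentration, so any difference in potency among these compounds remains open too.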